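The source may hold more compounds than are shown below. What is called first, only, known or untested is meant among the compounds shown, and "the series" means these compounds.

Values in an ADME assay for permeability, using PAMPA, with a stated time of 10 h, tested at 100 ug/mL; on this read-out higher numbers stand for higher permeability and lower numbers for lower permeability:

- Compound 1 `Oc1cccc2ccc(-c3cc4ccccc4[nH]3)nc12`: 8 10^-6 cm/s
- Compound 2 `Oc1c(Cl)cc(Cl)c2ccc(-c3cc4ccccc4[nH]3)nc12`: 6.6 10^-6 cm/s
- Compound 3 `Oc1ccc(-c2cc3ccccc3[nH]2)c2cccnc12`: 12.8 10^-6 cm/s

Compound 3 gives 12.8 10^-6 cm/s, which lies within the usual scatter of the values for compound 1 and compound 2, so these three cannot be told apart. Compound 4 `Oc1ccc2[nH]c(-c3ccc(O)c4ncccc34)cc2c1` is compound 3 with hydroxy in place of hydrogen on an aromatic carbon. Within the data shown here, no measured pair of compounds shows this kind of change, so the expectation rests on the structural change alone: a moderate step to a lower number in this assay, probably just beyond the scatter. The estimated change is a 2.3-fold lower number from compound 3 to compound 4 (0.37 log units; beyond the scatter). For compound 4, the estimated value is 5.5 10^-6 cm/s, with an expected range of 2 10^-6 cm/s to 11 10^-6 cm/s.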

Compound 4, apparent permeability: 9.1 10^-6 cm/s
Estimate against measurement, compound 4: 1.7-fold (0.22 log units) below, and the stated range covers the measured number.
By their numbers in this assay, from the lowest: compounds 2, 1, 4 and 3 (each within the scatter of the next).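

In this assay, putting hydroxy in place of hydrogen on an aromatic carbon of the six-membered carbon-only ring gives a 1.4-fold lower number from compound 3 to compound 4 (0.15 log units; within the scatter). Among these compounds, this is the first single change that can be read here, and at this position it leaves compound 3 and compound 4 impossible to tell apart. Nothing shown gives a reason for this result. From the compounds shown here alone, whether an amine, a carboxylic acid or a methoxy group at the same place would also stay within the scatter remains open. So does whether hydroxy on another carbon of this ring would do the same.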